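Stripping the Amide Aryl Group in an Orexin-2 Antagonist Series

The source may report more compounds than this note shows. Statements on the series, on what has been measured and on what is new or still open speak of the compounds shown alone.

compound 1 `Cc1cccc(NC(=O)CSc2nnc(-c3ccoc3C)n2Cc2ccco2)c1` — 50.1 nM
compound 2 `Cc1occc1-c1nnc(SCC(=O)Nc2cccc(F)c2)n1Cc1ccco1` — 501 nM
compound 3 `COc1ccccc1NC(=O)CSc1nnc(-c2ccoc2C)n1Cc1ccco1` — 501 nM

These three compounds were measured in a functional assay on CHO cells for antagonist activity at Orexin receptor type 2 (Homo sapiens), read by FLIPR and calcium flux; a lower number here means a stronger inhibitor, a higher number a weaker inhibitor. Compound 3 is level with compound 2 at the digits given, and the two together give the highest numbers of the three; compound 1 gives the lowest, the step being a 10-fold higher number from compound 1 to compound 3 (1.00 log units; beyond the scatter). Compound 4 `Cc1occc1-c1nnc(SCC(N)=O)n1Cc1ccco1` differs from compound 3 by hydrogen in place of 2-methoxyphenyl on an amide-type nitrogen. The steps touching the same amide nitrogen bear on this: a 10-fold higher number from compound 1 to compound 3 (1.00 log units; beyond the scatter) and no change at the digits printed from compound 2 to compound 3 (within the scatter). Both exchange one aryl group for another; neither removes it, so the present change goes beyond anything measured. Losing the whole aryl group is expected to weaken inhibition markedly, a step of a 20-fold higher number from compound 3 to compound 4 (1.30 log units; beyond the scatter) in this assay. Compound 4 is therefore estimated at 10000 nM, within a range from 2000 nM to 50000 nM.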

Compound 4, inhibition constant: > 15800 nM
Compound 4: no number, only a limit; the forecaster's own chance of this, stated with the estimate: 40%; middle value at least 1.5-fold (0.19 log units) away from the limit.
By their numbers in this assay, from the lowest: compound 1; then compounds 2 and 3 (each within the scatter of the next). At a limit, above all of these: compound 4.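

In this assay compound 4 gives no number, only a limit: the limit of > 15800 nM in this assay, at which 1 of the 4 values shown sits. Removing the aryl group from the amide nitrogen therefore goes further than exchanging it for another aryl group, with an at least 31-fold higher number from compound 3 to compound 4 (1.49 log units; beyond the scatter), an at least 31-fold higher number from compound 2 to compound 4 (1.49 log units; beyond the scatter) and an at least 310-fold higher number from compound 1 to compound 4 (2.49 log units; beyond the scatter). Of the four compounds, only those carrying an aryl group on that nitrogen give a number. How far compound 4 lies past its limit cannot be read. From the compounds shown here alone, whether a methyl or a benzyl group on that nitrogen would restore inhibition remains open.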